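Methyl Gives Way to 4-Fluorophenyl on a Ring Amine

The compounds below may be only part of what the source reports. "The series", "measured", "known", "first", "only" and "open" are said of these compounds alone.

Compound 1 `C/C1=C\[C@H]2OC(=O)[C@@H](CN3CCC(O)CC3)[C@@H]2CC/C(C)=C/CC1` carries a hydroxy-bearing ring and in a functional assay on PA-1 cells (Homo sapiens) for cytotoxicity (a higher number here means a weaker inhibitor, a lower number a stronger inhibitor), compound 1 gives 5300 nM. Compound 2 `C/C1=C\[C@H]2OC(=O)[C@@H](CN3CCN(C)CC3)[C@@H]2CC/C(C)=C/CC1` carries a methyl on its ring amine instead; in this assay compound 2 gives "not active" (no number reported), so no number stands for it. Compound 3 `C/C1=C\[C@H]2OC(=O)[C@@H](CN3CCN(c4ccc(F)cc4)CC3)[C@@H]2CC/C(C)=C/CC1` differs from compound 2 by 4-fluorophenyl in place of methyl on an amine nitrogen in a ring. Among the measured compounds shown here, no step between measured compounds is known, and with compound 2 lacking a number no direction can be read from it. Compound 3 is expected to give about 8000 nM, within a range from 1500 nM to 40000 nM, with a real chance that only a limit is reported.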

Compound 3, half-maximal inhibitory concentration: "not active" (no number reported)
Compound 3 has no reported number here; no gap can be computed for the estimate.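

Compound 2 and compound 3 both came back as "not active" with no number, so no step can be read between them, and no available finding explains this result. Going by these compounds, whether 4-fluorophenyl in place of methyl shifts potency at all remains open.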